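Cyclopentenyl in Place of Isopropyl on the Shared Core

This account rests on a few compounds, and the source may have more. Where it says the series, first, only, none or still open, it means among the compounds named here.

Compound 1, `Cc1c(C(=O)Nc2ccc(Oc3ncnc4[nH]cc(-c5ccccc5)c34)c(F)c2)c(=O)c2ccccc2n1C` — > 10000 nM
Compound 2, `Cc1c(C(=O)Nc2ccc(Oc3ncnc4[nH]cc(-c5ccccc5)c34)c(F)c2)c(=O)c2cc(F)ccc2n1C` — > 10000 nM
Compound 3, `Cc1c(C(=O)Nc2ccc(Oc3ncnc4[nH]cc(-c5ccccc5)c34)c(F)c2)c(=O)c2cc(C(C)C)ccc2n1C` — 26 nM

In an assay on isolated protein for inhibition of tyrosine-protein kinase receptor UFO (Homo sapiens), read by FRET and Z'-LYTE, with a stated time of 1.5 h (a lower number here means a stronger inhibitor, a higher number a weaker inhibitor), compound 1 reaches only a limit, not a number. The same holds for compound 2, whose value in this assay is also a limit. Compound 3 is therefore the only one of the three with a measured number, and the other two sit at the limit of > 10000 nM in this assay, at which 2 of the 3 values shown sit. The step of an at least 380-fold lower number from compound 1 to compound 3 (2.58 log units; beyond the scatter) and the step of an at least 380-fold lower number from compound 2 to compound 3 (2.58 log units; beyond the scatter) are both large, so the isopropyl on the aromatic carbon is tied to the only strong inhibition seen here.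

Compound 4, `Cc1c(C(=O)Nc2ccc(Oc3ncnc4[nH]cc(-c5ccccc5)c34)c(F)c2)c(=O)c2cc(C3=CCCC3)ccc2n1C`, carries cyclopent-1-en-1-yl in place of isopropyl on an aromatic carbon. Among the compounds with values here, no measured step describes this change directly; the steps that bear on it are an at least 380-fold lower number from compound 1 to compound 3 (2.58 log units; beyond the scatter) and an at least 380-fold lower number from compound 2 to compound 3 (2.58 log units; beyond the scatter), which show that a larger carbon group at this place is where the gain lies. Cyclopent-1-en-1-yl keeps a carbon group of comparable size there, so the expected step of a 1.2-fold higher number from compound 3 to compound 4 (0.06 log units; within the scatter) is one within the scatter, with no direction favored. Compound 4 is estimated at 30 nM, between 10 nM and 120 nM, in this assay.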

Compound 4, half-maximal inhibitory concentration: 3320 nM
Compound 4: middle estimate off by 110-fold (2.04 log units), on the low side; the measured number lies above the stated range.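

In this assay, within the data shown here, the place on the aromatic carbon proves far more selective than the earlier compounds could show: replacing isopropyl with cyclopent-1-en-1-yl, another all-carbon group with no hydrogen-bond donors or acceptors, gives a 130-fold higher number from compound 3 to compound 4 (2.11 log units; beyond the scatter), so carbon at this place does not by itself secure the strong inhibition of compound 3. Cyclopent-1-en-1-yl still retains part of the gain, with an at least 3.0-fold lower number from compound 1 to compound 4 (0.47 log units; beyond the scatter) and an at least 3.0-fold lower number from compound 2 to compound 4 (0.47 log units; beyond the scatter), which places compound 4 apart from the hydrogen and fluoro compounds as well as from compound 3. These two steps give only a minimum size, since compound 1 and compound 2 each stand at a limit of the assay, not at a number: the limit of > 10000 nM in this assay, at which 2 of the 4 values shown sit.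

The change brings in a ring, a double bond and more carbon atoms all at once, so the compounds shown do not tell which of these goes with the loss. A saturated cyclopentyl or a cyclopropyl at this place would help separate them, and an amine there would test whether anything other than a carbon group is accepted.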